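The compounds below may be only part of what the source reports. "The series", "measured", "known", "first", "only" and "open" are said of these compounds alone.

Measured so far:
Compound 1, `O=c1cc(-c2ccc(Cl)cc2)oc2cc(OCCBr)ccc12`: 119 nM
Compound 2, `O=c1cc(-c2ccc(Cl)cc2)oc2cc(OCCCBr)ccc12`: 679 nM
Compound 3, `O=c1cc(-c2ccccc2)oc2cc(OCCCCBr)ccc12`: 290 nM

All three compounds share one core, a flavone-like scaffold, and were tested in a functional assay for antagonist activity at Adrenergic receptor alpha-1 (Rattus norvegicus); a higher number here means weaker binding, a lower number tighter binding. Compound 3 stands second highest of the three numbers: compound 2 gives a higher number, compound 1 a lower one, and both gaps are beyond the usual scatter.

Compound 4, `O=c1cc(-c2ccc(Cl)cc2)oc2cc(OCCCCBr)ccc12`, has not been measured yet. It differs from compound 3 in one place: chloro in place of hydrogen on an aromatic carbon, that is, one heavy atom, a chlorine, enters on the ring that hangs from the core, making a 4-chlorophenyl out of a phenyl.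

For the measured compounds named here, none of the measured steps tests this change directly. Going by the values given here, the only single-point step on record, a 5.7-fold higher number from compound 1 to compound 2 (0.76 log units; beyond the scatter), concerns the bromoalkyl chain, not the aromatic ring. Among the compounds with values here, compounds 1 and 2 carry the chloro already but with shorter chains than compound 3, so no pair shows hydrogen against chloro with everything else equal. There is therefore no basis to expect a step beyond the scatter in this assay in either direction; the expected change is a 1.2-fold lower number from compound 3 to compound 4 (0.06 log units; within the scatter).

Compound 4 is estimated at 250 nM, with a range from 80 nM to 900 nM.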

Compound 4, dissociation constant: 429 nM
The estimate for compound 4 lay 1.7-fold (0.23 log units) below the measured number, within the range that was stated.
By their numbers in this assay, from the lowest: compound 1; then compounds 3, 4 and 2 (each within the scatter of the next, the first and the last beyond it).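

Putting chloro on the ring that hangs from the core, turning phenyl into 4-chlorophenyl, gives a 1.5-fold higher number from compound 3 to compound 4 (0.17 log units; within the scatter) in this assay, so with this bromoalkyl chain attached, the change cannot be told apart from repeat-measurement noise. Compound 4 also lets the chain be compared with the 4-chlorophenyl held constant: a 1.6-fold lower number from compound 2 to compound 4 (0.20 log units; within the scatter) shows no order between those two chains, whereas a 3.6-fold higher number from compound 1 to compound 4 (0.56 log units; beyond the scatter) shows that the chain of compound 1 gives a clearly lower number, which here means tighter binding. Nothing measured here explains either the chloro result or the chain result.

The compounds shown carry only hydrogen or chloro at this ring position, so the effect of a fluoro or a methoxy group there remains open, as does the effect of an amine in place of the bromo at the chain end. From the compounds shown here alone, whether chloro would give a similarly small step on the shorter chains also remains open; compound 1 and compound 2 appear here only with the chloro in place.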